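Dimethylamino in Place of Methoxy on the Aromatic Ring

The source may hold more compounds than are shown below. What is called first, only, known or untested is meant among the compounds shown, and "the series" means these compounds.

Measured so far:
compound 1 `CCc1nc2c(-c3ccc(OC)nc3C(F)(F)F)ccnc2n1C(CC)C1CC1`: 0.7 nM
compound 2 `CCc1nc2c(-c3ccc(OC)nc3C)ccnc2n1C(CC)C1CC1`: 0.7 nM
compound 3 `CCc1nc2c(-c3ccc(OC)nc3C)ccnc2n1C(C)CC`: 9.2 nM

Of the compounds shown here, three built on a shared core have been tested in an assay for binding affinity to Corticotropin releasing factor receptor (Rattus norvegicus); on this read-out higher numbers stand for weaker inhibition and lower numbers for stronger inhibition. Compound 2 stands level with compound 1, the step of no change at the digits printed from compound 1 to compound 2 (within the scatter) lying within the scatter, and the two together give the lowest numbers of the three. Compound 3 sits far from compound 2: the step of a 13-fold higher number from compound 2 to compound 3 (1.12 log units; beyond the scatter) is large. It goes with a change on the saturated chain carbon.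

The change now in view is dimethylamino in place of methoxy on an aromatic carbon, turning compound 2 into compound 4 `CCc1nc2c(-c3ccc(N(C)C)nc3C)ccnc2n1C(CC)C1CC1`. Neither measured step touches the methoxy: no change at the digits printed from compound 1 to compound 2 (within the scatter) concerned a different aromatic carbon and showed nothing beyond the scatter, while a 13-fold higher number from compound 2 to compound 3 (1.12 log units; beyond the scatter) concerned the chain carbon. Going by the values given here, no measured step bears directly on this change, so the expectation rests on the quiet aromatic swap seen in no change at the digits printed from compound 1 to compound 2 (within the scatter) and is for a step of a 2.1-fold higher number from compound 2 to compound 4 (0.33 log units; beyond the scatter), near the scatter. Compound 4 is therefore estimated at 1.5 nM, with a range from 0.4 nM to 6 nM.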

Compound 4, inhibition constant: 7.5 nM
For compound 4 the middle estimate is 5.0-fold (0.70 log units) below the measured one; measured number above the stated range.
By their numbers in this assay, from the lowest: compounds 1 and 2 (each within the scatter of the next); then compounds 4 and 3 (each within the scatter of the next).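

In this assay, dimethylamino in place of methoxy gives an 11-fold higher number from compound 2 to compound 4 (1.03 log units; beyond the scatter), so this aromatic carbon is sensitive to change, unlike the other aromatic carbon, where no change at the digits printed from compound 1 to compound 2 (within the scatter) stayed within the scatter. The two groups have the same counts of hydrogen-bond donors and acceptors and neither carries a net charge, yet the swap of methoxy, with 2 heavy atoms, for dimethylamino, with 3, is enough for a large step. Nothing available explains why this swap has such an effect.

The compounds shown leave open whether the step follows the nitrogen or the extra carbon at this position. An ethoxy group or a methylamino group here would help separate the two, and a bare hydroxyl group would show how much of the methoxy is needed at all.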